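The source may report more compounds than this note shows. Statements on the series, on what has been measured and on what is new or still open speak of the compounds shown alone.

Series notes, measured so far in a functional assay on A549 cells (Homo sapiens) for cytotoxicity, read by MTT assay, with a stated time of 48 h; on this read-out lower numbers stand for stronger inhibition and higher numbers for weaker inhibition:

- compound 1 `Cc1ccc(C)c(/C=C/[C@](C)(O)CC[C@@H]2[C@@]3(C)CCCC(C)(C)[C@@H]3CC[C@@]2(C)O)c1`: 3320 nM
- compound 2 `COc1cccc(/C=C/[C@](C)(O)CC[C@@H]2[C@@]3(C)CCCC(C)(C)[C@@H]3CC[C@@]2(C)O)c1OC`: 3280 nM

Compound 2 stands level with compound 1, and the two values cannot be told apart. Within the data shown here, the only measured step, a 1.0-fold lower number from compound 1 to compound 2 (0.01 log units; within the scatter), exchanged one substituted phenyl for another on the shared core and stayed within the scatter.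

The next structure is compound 3 `CC1(C)CCC[C@]2(C)[C@@H](CC[C@@](C)(O)/C=C/c3ccc(C(=O)O)cc3)[C@](C)(O)CC[C@@H]12`, and the change is 4-carboxyphenyl in place of 2,3-dimethoxyphenyl on a double-bonded chain carbon bound to a double-bonded chain carbon. Among the measured compounds shown here, the 4-carboxyphenyl group has no measured counterpart, so the step measured so far covers it only loosely. That step, a 1.0-fold lower number from compound 1 to compound 2 (0.01 log units; within the scatter), shows tolerance for one aryl exchange, but it says nothing direct about a carboxyl-bearing ring. A modest move toward a higher number in this assay is expected, with a real chance of no shift beyond the scatter. The expected step is a 1.5-fold higher number from compound 2 to compound 3 (0.18 log units; within the scatter). With compound 2 at 3280 nM as the reference, the estimate for compound 3 is 5000 nM. For the measured compounds named here, the expected range for compound 3 runs from 2000 nM to 15000 nM, kept wide since only two measured compounds support it.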

Compound 3, half-maximal inhibitory concentration: 44300 nM
Compound 3: the middle estimate sits 8.9-fold (0.95 log units) below what was measured; measured number above the stated range.
By their numbers in this assay, from the lowest: compounds 2 and 1 (each within the scatter of the next); then compound 3.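

In this assay, the aryl group on a double-bonded chain carbon bound to a double-bonded chain carbon is not freely exchangeable, as a 1.0-fold lower number from compound 1 to compound 2 (0.01 log units; within the scatter) alone might have suggested: 4-carboxyphenyl brings a 14-fold higher number from compound 2 to compound 3 (1.13 log units; beyond the scatter), and the comparison with the 2,5-dimethylphenyl compound gives a 13-fold higher number from compound 1 to compound 3 (1.13 log units; beyond the scatter). Since compound 1 and compound 2 cannot be told apart, these two steps describe a single separation, with compound 3 standing apart from both earlier compounds on a change confined to this one group. Nothing available bears on why the number rises with this change.

The compounds shown leave open whether the step belongs to the carboxyl group itself or to any substituent carried as in 4-carboxyphenyl, which a methyl ester or a primary amide in place of the carboxyl would help to separate. On these data alone, it also remains open whether an unsubstituted phenyl would stand with compound 1 and compound 2 or with compound 3, since 4-carboxyphenyl differs from both earlier groups in more than one respect.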